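Stripping the aryl substituents on the phenylpropyl arm

This account rests on a few compounds, and the source may have more. Where it says the series, first, only, none or still open, it means among the compounds named here.

Compound 3 `N#CSc1ccc(CCCN2CCN(CCCN(c3ccc(F)cc3)c3ccc(F)cc3)CC2)cc1I` gives 95.5 nM in an assay on isolated protein (strain Sprague-Dawley) for displacement of a labelled ligand from sodium-dependent dopamine transporter (Rattus norvegicus) (on this read-out higher numbers stand for weaker inhibition and lower numbers for stronger inhibition), the second highest of three numbers; compound 1 `N#CSc1ccc(CN2CCN(CCCN(c3ccc(F)cc3)c3ccc(F)cc3)CC2)cc1` gives 75.4 nM, within scatter of it, while compound 2 `[N-]=[N+]=Nc1ccc(CN2CCN(CCCN(c3ccc(F)cc3)c3ccc(F)cc3)CC2)cc1I` gives 242 nM, and the step of a 2.5-fold lower number from compound 2 to compound 3 (0.40 log units; beyond the scatter) is modest. Compound 4 `Fc1ccc(N(CCCN2CCN(CCCc3ccccc3)CC2)c2ccc(F)cc2)cc1` carries phenyl in place of 4-(cyanosulfanyl)-3-iodophenyl on a saturated chain carbon, three bonds along the chain from an amine nitrogen in a ring. Among the compounds with values here, no measured step removes both aryl substituents at once; the nearest comparisons are a 3.2-fold higher number from compound 1 to compound 2 (0.51 log units; beyond the scatter), where exchanging aryl substituents shifted the number modestly, and a 1.3-fold higher number from compound 1 to compound 3 (0.10 log units; within the scatter), where a longer chain with an added iodine stayed within scatter. A step of at most modest size is therefore expected, direction uncertain. For compound 4 the estimate is 110 nM, range 40 nM to 320 nM, which corresponds to an expected step of a 1.2-fold higher number from compound 3 to compound 4 (0.06 log units; within the scatter).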

Compound 4, half-maximal inhibitory concentration: 19.5 nM
Compound 4: middle estimate off by 5.6-fold (0.75 log units), on the high side, and the stated range ends above it.
By their numbers in this assay, from the lowest: compound 4; then compounds 1 and 3 (each within the scatter of the next); then compound 2.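

Phenyl with no substituent at this position, three bonds along the chain from an amine nitrogen in a ring, gives the lowest number so far (a 4.9-fold lower number from compound 3 to compound 4 (0.69 log units; beyond the scatter)), so neither the cyanosulfanyl nor the iodine is required for stronger inhibition. Phenethyl also improves on 4-(cyanosulfanyl)phenyl (a 3.9-fold lower number from compound 1 to compound 4 (0.59 log units; beyond the scatter)) and on 4-azido-3-iodophenyl (a 12-fold lower number from compound 2 to compound 4 (1.09 log units; beyond the scatter)), the latter being the only large step in the series. No available evidence accounts for these steps.

Still open, going by these compounds, is whether iodine alone or cyanosulfanyl alone on the phenyl retains this gain. A longer chain, or an amine or carboxylic acid on the phenyl, also remains untested in the compounds shown.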